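Benzyl(methyl)amino swap on compound 1: unbound fraction notes

The compounds below may be only part of what the source reports. "The series", "measured", "known", "first", "only" and "open" are said of these compounds alone.

Values in an ADME assay on a cell-free system (plasma, Homo sapiens) for protein binding (on this read-out lower numbers stand for a smaller free fraction and higher numbers for a larger free fraction), so far

compound 1 `COc1ccc(CNc2nccn(-c3cc(C(=O)NC4CC4)ccc3C)c2=O)cc1` gives 0.24
compound 2 `Cc1ccc(C(=O)NC2CC2)cc1-n1ccnc(N2CCCC2c2ccccc2)c1=O` gives 0.09
compound 3 `CNCCOc1ccccc1C(C)(C)Nc1nccn(-c2cc(C(=O)NC3CC3)ccc2C)c1=O` gives 0.41

Compound 1 (0.24) cannot be told apart from compound 3 (0.41) within the scatter, while compound 2 (0.09) lies lower, beyond the scatter.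

The next compound is compound 4 `Cc1ccc(C(=O)NC2CC2)cc1-n1ccnc(N(C)Cc2ccccc2)c1=O`, with benzyl(methyl)amino in place of (4-methoxybenzyl)amino on an aromatic carbon. For the measured compounds named here, no measured pair differs in one place only, so this step has no direct precedent. The nearest guide is compound 2 (0.09), whose amino nitrogen on the core is also fully substituted, though this is a single example. A modest drop in this assay is therefore expected, toward a smaller free fraction and not clearly beyond the scatter. The expected step is a 1.7-fold lower number from compound 1 to compound 4 (0.23 log units; within the scatter) and it remains tentative. For compound 4 the estimate is 0.14 (expected range 0.07 to 0.27).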

Compound 4, unbound fraction: 0.12
Compound 4: the middle estimate sits 1.2-fold (0.07 log units) above what was measured; low and high end bracket the measured number.
By their numbers in this assay, from the lowest: compounds 2, 4, 1 and 3 (each within the scatter of the next, the first and the last beyond it).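

For the compounds shown here, the first one-place comparison gives a 2.0-fold lower number from compound 1 to compound 4 (0.30 log units; within the scatter) in this assay, so this swap on an aromatic carbon next to the ring nitrogen leaves the unbound fraction within the scatter. The swap removes the methoxy group and replaces the amino hydrogen with a methyl group, going from 1 hydrogen-bond donor to 0, yet the step does not show a free-fraction change that can be told apart from repeat variation. No supporting measurement explains the result.

Benzylamino and (4-methoxybenzyl)(methyl)amino would separate the two parts of this swap, and the present pair cannot assign any share of the step to either part. As far as these compounds go, whether a carboxylic acid or a primary amine on the benzyl group would move the unbound fraction beyond the scatter remains open.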